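The compounds below may be only part of what the source reports. "The series", "measured", "known", "first", "only" and "open" are said of these compounds alone.

Compound 1 (`O=C(/C=C/c1ccc([N+](=O)[O-])cc1)c1ccc[nH]1`): 13000 nM
Compound 2 (`O=C(/C=C/c1cccc([N+](=O)[O-])c1)c1ccc[nH]1`): 23000 nM

Within the data shown here, both values come from a functional assay on PC-3 cells (Homo sapiens) for inhibition, read by MTT assay, with a stated time of 48 h (on this read-out lower numbers stand for stronger inhibition and higher numbers for weaker inhibition), and are the only numbers available so far. Compound 1 stands level with compound 2: their two values lie within the usual scatter of repeated measurements, so neither can be ranked over the other. Among the measured compounds shown here, no pair of measured compounds differs in just one place, so the data give no direct measure of what swapping a single group does.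

The next compound is compound 3 (`O=C(/C=C/c1ccc(Br)cc1)c1ccc[nH]1`), which keeps the core of compound 1. The counted difference is bromo in place of nitro on an aromatic carbon and in words it is bromo in place of nitro on an aromatic carbon. For the measured compounds named here, with no measured step to guide it, the expectation in this assay is for no change beyond the scatter, in either direction, and the margin must stay wide. It rests only on compound 1 at 13000 nM and compound 2 at 23000 nM lying so close together. The estimated step is a 1.2-fold higher number from compound 1 to compound 3 (0.06 log units; within the scatter) and would be a small one. For compound 3 the expected value is 15000 nM with an estimated range from 6000 nM to 40000 nM in repeat measurements.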

Compound 3, half-maximal inhibitory concentration: 44000 nM
Compound 3: the middle estimate sits 2.9-fold (0.47 log units) below what was measured; measured number outside the range, above it.
By their numbers in this assay, from the lowest: compounds 1, 2 and 3 (each within the scatter of the next, the first and the last beyond it).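

In this assay, among these compounds, the swap of bromo in place of nitro gives a 3.4-fold higher number from compound 1 to compound 3 (0.53 log units; beyond the scatter) and is the first single-place change that can be read directly. It shows that this spot on the six-membered aromatic ring, para to a group of 9 heavy atoms, does not treat the two groups alike: the step lies beyond the scatter, and the nitro compound is on the side of stronger inhibition. The step is modest, and with no measurement available to explain it, the counted differences between the two groups, in heavy atoms and in hydrogen-bond acceptors, remain descriptions and not a cause.

A single swap cannot show whether the nitro group is specially favoured here or bromo is specially disfavoured, so other groups at this spot, such as an amine, a methoxy group or a carboxylic acid, would be needed to place both on a wider scale. The compounds shown also leave open whether bromo in place of nitro would have a similar effect at the spot that carries the nitro group in compound 2.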